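This account rests on a few compounds, and the source may have more. Where it says the series, first, only, none or still open, it means among the compounds named here.

Within the data shown here, only two compounds have been tested so far in a physicochemical assay for permeability, using PAMPA; a higher number here means that the compound crosses the layer faster, a lower number that the compound crosses the layer more slowly. Compound 1 (`COCCOc1cc2oc(=O)n(CCC(=O)O)c2cc1Cl`) gives < 3 nm/s, and this is a limit of the assay and not a number. Among the measured compounds shown here, compound 2 (`C[C@@H](Oc1cc2oc(=O)n(CCC(=O)O)c2cc1Cl)c1ccc(Cl)cn1`) gives 60 nm/s, which makes it the only compound so far with a true number.

Compound 3 (`C[C@@H](Oc1cc2oc(=O)n(CCC(=O)O)c2cc1Cl)c1ncccn1`) has not yet been measured. It keeps the shared core of compound 2 but carries pyrimidin-2-yl in place of 5-chloropyridin-2-yl on a saturated chain carbon bound to an oxygen on an aromatic ring and a saturated chain carbon.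

For the measured compounds named here, no measured pair of compounds shows what this swap does in this assay, so the size of the change has to be judged rather than read from the data. The expectation is a fall that goes beyond the usual scatter, starting from the 60 nm/s of compound 2. The estimated step, a 6.0-fold lower number from compound 2 to compound 3 (0.78 log units; beyond the scatter), is therefore a clear drop, though an uncertain one. For compound 3 the expected value is 10 nm/s, with an estimated range of 3 nm/s to 30 nm/s.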

Compound 3, apparent permeability: < 3 nm/s
Compound 3: only a limit was reported; the forecaster's own chance of this, stated with the estimate: 20%; at least 3.3-fold (0.52 log units) between middle value and limit.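

In this assay, among these compounds, the first step that can be read at this position comes from putting pyrimidin-2-yl in place of 5-chloropyridin-2-yl on a saturated chain carbon bound to an oxygen on an aromatic ring and a saturated chain carbon: an at least 20-fold lower number from compound 2 to compound 3 (1.30 log units; beyond the scatter) is a large change, so a modest swap of one aromatic ring for another is enough to move this read-out far beyond the usual scatter. Compound 3 gives < 3 nm/s, which is a limit of the assay and not a number. The step from compound 1 to compound 3 cannot be read because both compounds stand at a limit, so only compound 2 keeps a true number so far: the limit of < 3 nm/s in this assay, at which 2 of the 3 values shown sit.

The swap removes the chlorine and adds a ring nitrogen in one move, so these compounds cannot tell which of the two changes accounts for the drop. A plain pyridin-2-yl ring, which has no chlorine and a single ring nitrogen, or a 5-chloropyrimidin-2-yl ring, which keeps the chlorine and has both ring nitrogens, would separate the two changes on this same carbon.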